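The source may report more compounds than this note shows. Statements on the series, on what has been measured and on what is new or still open speak of the compounds shown alone.

Within the data shown here, in a functional assay on V79 cells (Cricetulus griseus) for cytotoxicity, read by colony formation (a lower number here means a stronger inhibitor, a higher number a weaker inhibitor), two compounds sharing one core have numbers so far. Compound 1 `CNCC1(C)CCN(c2c(F)cc3c(=O)c(C(=O)O)cn(C4CC4)c3c2C(F)(F)F)C1` gives 230 ug/mL, and compound 2 `NC1CCCN(c2c(F)cc3c(=O)c(C(=O)O)cn(C4CC4)c3c2Cl)C1` gives 24 ug/mL. Compound 2 therefore stands lowest of the two, and its gap to compound 1 lies beyond the usual scatter. Compound 3 `NC1CCCN(c2c(F)cc3c(=O)c(C(=O)O)cn(C4CC4)c3c2C(F)(F)F)C1` keeps the 3-aminopiperidin-1-yl group of compound 2 and changes one substituent: trifluoromethyl in place of chloro on an aromatic carbon. This places trifluoromethyl in place of chloro on an aromatic carbon, ortho to the 3-aminopiperidin-1-yl group. Among the measured compounds shown here, no measured pair isolates this change, so the size of the step is not known directly. For the measured compounds named here, the only measured compound with trifluoromethyl is compound 1 at 230 ug/mL, but it also differs from compound 2 in the group attached to the core, so it offers only a weak guide. A moderate step towards a higher number in this assay is expected, possibly not far beyond the scatter. For compound 3 the estimated value is 70 ug/mL, with an expected range of 20 ug/mL to 230 ug/mL. This estimate corresponds to an expected 2.9-fold higher number from compound 2 to compound 3 (0.46 log units; beyond the scatter).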

Compound 3, half-maximal inhibitory concentration: > 500 ug/mL
Compound 3 was reported as a limit (the forecaster's own chance of this, stated with the estimate: 5%); middle value at least 7.1-fold (0.85 log units) from the limit.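

In this assay, trifluoromethyl in place of chloro on the aromatic carbon ortho to the 3-aminopiperidin-1-yl group now has a measured size with that group held fixed, and it is a large step towards a weaker inhibitor: an at least 20-fold higher number from compound 2 to compound 3 (1.31 log units; beyond the scatter). Compound 3 stands at a limit of the assay and not at a number, so this step and the next one are lower bounds: the limit of > 500 ug/mL in this assay, at which 1 of the 3 values shown sits. With trifluoromethyl held fixed on the shared core, 3-aminopiperidin-1-yl in place of 3-methyl-3-((methylamino)methyl)pyrrolidin-1-yl also gives a step that is at least modest, an at least 2.1-fold higher number from compound 1 to compound 3 (0.33 log units; beyond the scatter), so the number responds to a change in either of these two places.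

As far as these compounds go, whether a methyl or a methoxy group on this aromatic carbon would give a number nearer that of compound 2 or that of compound 3 remains open. Also open is whether the step from chloro to trifluoromethyl keeps its size with the 3-methyl-3-((methylamino)methyl)pyrrolidin-1-yl group, as the compounds shown pair chloro and trifluoromethyl only with the 3-aminopiperidin-1-yl group.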